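The source may report more compounds than this note shows. Statements on the series, on what has been measured and on what is new or still open speak of the compounds shown alone.

Measured so far in a functional assay on MCF7 cells (Homo sapiens) for inhibition, read by MTT assay, with a stated time of 72 h, tested at 30 uM; on this read-out higher numbers stand for more inhibition of growth at the one concentration tested and lower numbers for less inhibition of growth:
- compound 1 `C=CCc1ccc(OCc2cn(-c3ccccc3CO)nn2)c(O)c1`: 34.5%
- compound 2 `C=CCc1ccc(OCc2cn(-c3cccc(C#N)c3)nn2)c(O)c1`: 31.9%

In this assay, compound 2 gives 31.9%, which lies within the scatter of compound 1 at 34.5%. The two cannot be ranked on these numbers.

The next compound to be read is compound 3 `C=CCc1ccc(OCc2cn(-c3ccc(Br)cc3)nn2)c(O)c1`, with 4-bromophenyl in place of 3-cyanophenyl on an aromatic nitrogen. The shared core stays the same.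

Within the data shown here, only one measured step bears on this change, since it also swaps the group on that aromatic nitrogen: a number 2.6 percentage points lower from compound 1 to compound 2 (within the scatter). Among the measured compounds shown here, no measured compound here carries bromine, so the basis is thin and the range has to stay wide. With that single step as the guide, no change beyond the scatter is expected in this assay, and no direction can be argued from the data. The estimate corresponds to an expected a number 3.1 percentage points higher from compound 2 to compound 3 (within the scatter). The estimated value for compound 3 is 35%, with an expected range from 21% to 50%.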

Compound 3, percent growth inhibition at one concentration: 19.4%
For compound 3 the middle estimate is 15.6 percentage points above the measured one, and the stated range ends above it.
By their numbers in this assay, from the lowest: compound 3; then compounds 2 and 1 (each within the scatter of the next).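

In this assay the aryl group on the aromatic nitrogen of the five-membered ring now proves able to move the read-out: a number 12.5 percentage points lower from compound 2 to compound 3 (beyond the scatter) and a number 15.1 percentage points lower from compound 1 to compound 3 (beyond the scatter) are both printed for 4-bromophenyl, whereas the earlier exchange of 2-(hydroxymethyl)phenyl for 3-cyanophenyl gave a number 2.6 percentage points lower from compound 1 to compound 2 (within the scatter) and separated nothing. The position is therefore not indifferent to its substituent, and with the shared core unchanged, compound 3 stands apart from both compound 1 and compound 2, which themselves cannot be ranked. Nothing available on these compounds accounts for the lower inhibition of growth seen with 4-bromophenyl.

Going by these compounds, each step to compound 3 changes the substituent and its place on the phenyl ring together, so it stays open whether the lower number goes with bromine itself or with the 4-position; 3-bromophenyl and 4-cyanophenyl would separate the two. Also open, on these data alone, is how this position reads with an amine or a carboxylic acid on the phenyl ring, or with a longer chain in place of the phenyl ring.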